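Dimethylamino in place of amino on a weak inhibitor

A few compounds are considered here, and "the series" means these few. Any claim that something is new, unique, unknown or untested is made for them only; others in the source may bear on it.

Among the compounds with values here, in a functional assay on NCI-H460 cells (Homo sapiens) for inhibition (on this read-out higher numbers stand for weaker inhibition and lower numbers for stronger inhibition), compound 1 (`COc1cc(-n2cncc2-c2ccc(N)cc2)cc(OC)c1OC`) gives 8550 nM as its reading, the higher of the two numbers known so far. In this assay compound 2 (`COc1ccc(-c2ccnn2-c2cc(OC)c(OC)c(OC)c2)cc1N`) gives 33 nM as its reading, a far lower number and well beyond the scatter, which leaves compound 1 as the weaker inhibitor of the pair. Compound 3 (`COc1cc(-n2cncc2-c2ccc(N(C)C)cc2)cc(OC)c1OC`) keeps the core of compound 1 and alters a single group, with dimethylamino in place of amino on an aromatic carbon, para to a large group (dimethylamino in place of amino on an aromatic carbon). Within the data shown here, no measured pair shows this change, and compound 1 and compound 2 differ in more than one place, so their gap cannot be carried over to it. A modest step toward stronger inhibition is expected in this assay for this change, small beside that gap, and a step within the scatter remains possible. In numbers, the expected shift is a 2.1-fold lower number from compound 1 to compound 3 (0.33 log units; beyond the scatter) by this estimate. For compound 3 the estimated value is 4000 nM within an expected range of 600 nM to 20000 nM on this read-out.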

Compound 3, half-maximal inhibitory concentration: 79 nM
Beside the measured number, compound 3's estimate is 51-fold (1.70 log units) above it, outside the stated range (below it).
By their numbers in this assay, from the lowest: compound 2; then compound 3; then compound 1.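

In this assay, within the data shown here, replacing amino with dimethylamino on an aromatic carbon, para to a large group, gives a 110-fold lower number from compound 1 to compound 3 (2.03 log units; beyond the scatter) and provides the first measured single-place comparison in this set. It shows that inhibition on the core of compound 1 depends strongly on the group at this position, and that this change moves the reading in the direction of stronger inhibition. The change adds two carbon atoms and removes the one hydrogen-bond donor of amino, but no measurement here bears on why the step is so large.

Among these compounds, with only this pair, the contribution of the added carbons cannot be separated from that of the lost donor, and methylamino, which would stand as the intermediate case, or diethylamino, which would extend the substituents further, would be needed to show how the reading follows the group at this position. Going by these compounds, whether dimethylamino in place of amino would give a step of similar size on compound 2, which carries its amino group on a different core, also remains open.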